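From 1H-pyrrol-2-yl to 1H-pyrazol-1-yl: working notes

The source may report more compounds than this note shows. Statements on the series, on what has been measured and on what is new or still open speak of the compounds shown alone.

compound 1 `c1ccc2[nH]c(-n3cccn3)cc2c1` gives > 100000 nM as a limit
compound 2 `COc1ccc2[nH]c(-c3ccc[nH]3)cc2c1` gives 84000 nM as a number

Going by the values given here, in a functional assay on MCF7 cells (Homo sapiens) for cytotoxicity, read by MTT assay, with a stated time of 72 h (on this read-out lower numbers stand for stronger inhibition and higher numbers for weaker inhibition), compound 2 at 84000 nM holds the only actual number so far. Compound 3 `COc1ccc2[nH]c(-n3cccn3)cc2c1` is still unmeasured. It has 1H-pyrazol-1-yl in place of the 1H-pyrrol-2-yl of compound 2 1H-pyrazol-1-yl in place of 1H-pyrrol-2-yl on an aromatic carbon on an aromatic carbon of a five-membered aromatic ring with 1 nitrogen, part of a fused or bridged system of two rings, next to the ring nitrogen. Compound 1 also carries 1H-pyrazol-1-yl, and its > 100000 nM in this assay is a limit and not a number. This limit for compound 1 points toward weaker inhibition, if there is any change. The estimated 1.1-fold higher number from compound 2 to compound 3 (0.03 log units; within the scatter) in this assay is expected to stay within the usual scatter. For compound 3 the estimated value is 90000 nM with an expected range from 35000 nM to 200000 nM and a report as a limit is also quite possible.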

Compound 3, half-maximal inhibitory concentration: > 100000 nM
Compound 3: only a limit was reported; the forecaster's own chance of this, stated with the estimate: 50%; middle value at least 1.1-fold (0.04 log units) away from the limit.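

In this assay, this change at the carbon next to the ring nitrogen, with methoxy kept in both compounds, gives an at least 1.1-fold higher number from compound 2 to compound 3 (0.07 log units; that floor lies within the scatter). Going by these compounds alone, this is the first readable step at this position, and it shows that 1H-pyrazol-1-yl in place of 1H-pyrrol-2-yl gives no sign of stronger inhibition, although how far the number rises is not fixed and the floor alone shows no real loss. The step for methoxy in place of hydrogen cannot be read, and the true size of the ring change stays hidden because the values pile up at the assay's ceiling: the limit of > 100000 nM in this assay, at which 2 of the 3 values shown sit.

Still open, going by these compounds, is whether methoxy has any effect on this read-out. Also open, on these data alone, is whether an amine or a carboxylic acid at this position would give a measurable number under the limit.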